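From cyclohexylamino to anilino, starting at a limit

The source may report more compounds than this note shows. Statements on the series, on what has been measured and on what is new or still open speak of the compounds shown alone.

Compound 1 `CC1(C)C(=O)N(c2ccc(SC(F)(F)F)cc2)C(=O)N1Cc1ccncc1`: < 0.02 ug/mL, a limit
Compound 2 `CC1(C)C(=O)N(c2ccc(SC(F)(F)F)cc2)C(=O)N1Cc1ccnc(NC2CCCCC2)c1`: < 0.025 ug/mL, a limit

In a physicochemical assay for solubility, read by nephelometry (a lower number here means a less soluble compound, a higher number a more soluble compound), compound 2 gives < 0.025 ug/mL, which is a limit and not a number. Compound 3 `CC1(C)C(=O)N(c2ccc(SC(F)(F)F)cc2)C(=O)N1Cc1ccnc(Nc2ccccc2)c1` carries phenyl in place of cyclohexyl on a nitrogen on an aromatic ring. For the measured compounds named here, the only measured step, a step that the two limits leave unreadable from compound 1 to compound 2, offers no size to carry over, so no change beyond the scatter is expected. The expected step is a number no lower from compound 2 to compound 3 (the limit leaves the size open). For compound 3 the estimate is 0.025 ug/mL, with an expected range of 0.01 ug/mL to 0.06 ug/mL.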

Compound 3, solubility: < 0.025 ug/mL
Compound 3: no number, only a limit; the forecaster's own chance of this, stated with the estimate: 80%; the middle value lies on the limit itself.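

In this assay, for the compounds shown here, compound 1, compound 2 and compound 3 all give limits and not numbers, so no step among them can be read. From the compounds shown here alone, the true values of all three remain open, as does any real difference between them.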